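Nitro in Place of Trifluoromethyl on a Well-Tolerated Core

The source may report more compounds than this note shows. Statements on the series, on what has been measured and on what is new or still open speak of the compounds shown alone.

Compound 1 `Clc1cccc(/N=N/N2CCCC2)c1` and compound 2 `FC(F)(F)c1cccc(/N=N/N2CCCC2)c1` share one core and differ in a single group. Both were tested in an ADME assay on BHK-21 cells (Mesocricetus auratus) for cytotoxicity, read by MTT assay, with a stated time of 96 h; a higher number here means that more compound is tolerated, a lower number that less compound is tolerated. Compound 1 gives > 100000 nM, which is a limit of the assay and not a number. Compound 2 gives > 100000 nM, again a limit and not a number. Within the data shown here, compound 2 therefore has no exact position, and the one measured step, a step that the two limits leave unreadable from compound 1 to compound 2, offers no size to carry forward.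

The next structure is compound 3 `O=[N+]([O-])c1cccc(/N=N/N2CCCC2)c1`, and the change leading to it is nitro in place of trifluoromethyl on an aromatic carbon. Among the measured compounds shown here, no tested compound yet carries nitro, so the only guide is the limit of > 100000 nM in this assay, at which 2 of the 2 values shown sit. The expectation leans on compound 2, whose > 100000 nM is a limit. No step beyond the usual scatter is expected in this assay, although any real shift could only appear as less compound tolerated. The expected step, a number no higher from compound 2 to compound 3 (the limit leaves the size open), is an estimate and may well stay unreadable. For compound 3 the estimated value is 100000 nM, with an expected range from 40000 nM to 150000 nM.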

Compound 3, half-maximal cytotoxic concentration: 42000 nM
The estimate for compound 3 lay 2.4-fold (0.38 log units) above the measured number; the measured number falls inside the stated range.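

This place on the ring is not indifferent to the group it carries: in this assay, nitro in place of trifluoromethyl gives an at least 2.3-fold lower number from compound 2 to compound 3 (0.37 log units; beyond the scatter), and nitro in place of chloro gives an at least 2.3-fold lower number from compound 1 to compound 3 (0.37 log units; beyond the scatter). Both steps lie beyond the usual scatter, and each gives only the smallest size the data allow, so the real drop in tolerated compound may be larger, while the step from compound 1 to compound 2 cannot be read. Compound 3 is the only compound here with a readable number, which gives the series its first measured point and makes nitro the one change shown that clearly lowers how much compound the cells tolerate: the limit of > 100000 nM in this assay, at which 2 of the 3 values shown sit.

Nitro brings hydrogen-bond acceptors where trifluoromethyl has none, but the compounds shown cannot tell whether that difference or some other feature of the nitro group lies behind the lower number. Also open, from the compounds shown here alone, is how an amine or a nitrile at the same place would fare, and how far compound 1 and compound 2 truly sit from compound 3.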